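Chloro for fluoro on the aryl urea of compound 3

The source may hold more compounds than are shown below. What is called first, only, known or untested is meant among the compounds shown, and "the series" means these compounds.

Compound 3 `COc1cc(NC(=O)N2C=CC(=O)C[C@H]2c2ccc(F)cc2)c(Br)cc1F` was measured in an assay on 1321-N1 cells for antagonist activity at P2X purinoceptor 7 (Homo sapiens), read by FLIPR, with stated times of 20 min, 1 s and 60 s, in the presence of a further agent that is not named here (on this read-out higher numbers stand for weaker inhibition and lower numbers for stronger inhibition), and gave 32 nM. Compound 1 `COc1cc(NC(=O)N2C=CC(=O)C[C@H]2c2ccccc2)c(Br)cc1Cl` gave 33 nM in this assay, and compound 2 `O=C1C=CN(C(=O)Nc2cc(OCCO)c(Cl)cc2Br)[C@H](c2ccc(F)cc2)C1` gave 40 nM; compound 3 sits within the scatter of both, so the three numbers cannot be told apart. Compound 4 `COc1cc(NC(=O)N2C=CC(=O)C[C@H]2c2ccc(F)cc2)c(Br)cc1Cl` has not yet been measured. It differs from compound 3 by chloro in place of fluoro on an aromatic carbon. Compound 1 already carries a chloro at that position and its value 33 nM matches that of compound 3, so no step beyond the scatter is expected. The estimated step from compound 3 to compound 4 is no change at the digits printed from compound 3 to compound 4 (within the scatter). Compound 4 is expected to give about 32 nM in this assay, within a range of 16 nM to 64 nM.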

Compound 4, half-maximal inhibitory concentration: 37 nM
Beside the measured number, compound 4's estimate is 1.2-fold (0.06 log units) below it, and the stated range covers the measured number.
By their numbers in this assay, from the lowest: compounds 3, 1, 4 and 2 (each within the scatter of the next).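

At this aromatic carbon, chloro in place of fluoro gives a 1.2-fold higher number from compound 3 to compound 4 (0.06 log units; within the scatter) in this assay, so the two halogens cannot be told apart here. The other two changes also stay within the scatter: fluoro in place of hydrogen on an aromatic carbon gives a 1.1-fold higher number from compound 1 to compound 4 (0.05 log units; within the scatter) and hydrogen in place of hydroxymethyl on the chain gives a 1.1-fold lower number from compound 2 to compound 4 (0.03 log units; within the scatter) and so neither shifts the number. Nothing at hand explains why these values lie so close.
The compounds shown leave open whether an amine or a carboxylic acid at this aromatic carbon would keep the number in the same range.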